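Amide aryl swap on the dinitro series: compound 4

This account rests on a few compounds, and the source may have more. Where it says the series, first, only, none or still open, it means among the compounds named here.

Measured compounds:
- compound 1, `O=C(/C=C/C(=O)N1C/C(=C\c2ccccc2)C(=O)/C(=C/c2ccccc2)C1)Nc1ccc(Cl)c(Cl)c1`, 7500 nM
- compound 2, `Cc1cccc(C)c1NC(=O)/C=C/C(=O)N1C/C(=C\c2ccc([N+](=O)[O-])cc2)C(=O)/C(=C/c2ccc([N+](=O)[O-])cc2)C1`, 690 nM
- compound 3, `Cc1ccc(NC(=O)/C=C/C(=O)N2C/C(=C\c3ccccc3)C(=O)/C(=C/c3ccccc3)C2)cc1`, 5800 nM

In a functional assay on L1210 cells (Mus musculus) for cytotoxicity (a higher number here means a weaker inhibitor, a lower number a stronger inhibitor), compound 2 gives the lowest number of the three; compound 3 is the nearest and compound 1 the furthest, both beyond the scatter. Among the compounds with values here, compound 2 is not linked to either by a single change, so no step involving it is known.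

Compound 4, `O=C(/C=C/C(=O)N1C/C(=C\c2ccc([N+](=O)[O-])cc2)C(=O)/C(=C/c2ccc([N+](=O)[O-])cc2)C1)Nc1ccccc1`, differs from compound 2 by phenyl in place of 2,6-dimethylphenyl on an amide-type nitrogen. Within the data shown here, the one change at the same position that has been measured is a 1.3-fold lower number from compound 1 to compound 3 (0.11 log units; within the scatter), within the scatter. By that analogy the step in this assay is expected to be small, a 1.2-fold higher number from compound 2 to compound 4 (0.09 log units; within the scatter), with no set direction. Compound 4 is therefore estimated at 850 nM, from 350 nM to 2200 nM.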

Compound 4, half-maximal inhibitory concentration: 1800 nM
For compound 4 the middle estimate is 2.1-fold (0.33 log units) below the measured one; measured number inside the range.
By their numbers in this assay, from the lowest: compound 2; then compound 4; then compounds 3 and 1 (each within the scatter of the next).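

In this assay the aryl group on the amide-type nitrogen can move the number: phenyl in place of 2,6-dimethylphenyl gives a 2.6-fold higher number from compound 2 to compound 4 (0.42 log units; beyond the scatter) and lies beyond the scatter, whereas the earlier swap gave a 1.3-fold lower number from compound 1 to compound 3 (0.11 log units; within the scatter) and stayed within it. These two steps share neither aryl pair nor core, so they cannot be set against each other directly. Nothing available bears on the reason for the new step.

Open, going by these compounds, is whether the same swap gives a similar step on the core of compound 1. Also open, on these data alone, is how a single methyl, an amine or a carboxylic acid on this phenyl would behave.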